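The compounds below may be only part of what the source reports. "The series", "measured", "known", "first", "only" and "open" are said of these compounds alone.

In a functional assay on A549 cells (Homo sapiens) for antiproliferative activity, read by MTT assay, with a stated time of 72 h (a lower number here means a stronger inhibitor, a higher number a weaker inhibitor), three compounds have been measured:

- compound 1 `COc1cccc(Nc2nc3c(c(Oc4cccc(NC(=O)/C=C/C(C)C)c4)n2)CSCC3)c1`: 25300 nM
- compound 2 `CC/C=C/C(=O)Nc1cccc(Oc2nc(Nc3ccc(OC)cc3)nc3c2CSCC3)c1`: 20100 nM
- compound 3 `CCC/C=C/C(=O)Nc1cccc(Oc2nc(Nc3ccc(OC)cc3)nc3c2CSCC3)c1`: 11900 nM

Compound 3 has a value within the scatter of that of compound 2, and its gap to the higher number of compound 1 lies just beyond the scatter. All three numbers are high in this assay.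

The next compound is compound 4 `COc1ccc(Nc2nc3c(c(Oc4cccc(NC(=O)/C=C/C(C)C)c4)n2)CSCC3)cc1`, which has isopropyl in place of propyl on a double-bonded chain carbon bound to a double-bonded chain carbon.

Among the compounds with values here, only one measured step changes this chain. In a 1.7-fold lower number from compound 2 to compound 3 (0.23 log units; within the scatter), methyl replaces hydrogen on a saturated chain carbon, and that step stays within the scatter. Compound 1 carries the same isopropyl and gives 25300 nM, but it differs from compound 4 elsewhere in the molecule, so it offers only a loose hint towards a higher number.

The expected change is therefore small, a 1.4-fold higher number from compound 3 to compound 4 (0.15 log units; within the scatter), and not expected to exceed the scatter. Compound 4 is estimated at 17000 nM, with an expected range from 9000 nM to 32000 nM.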

Compound 4, half-maximal inhibitory concentration: 25900 nM
Beside the measured number, compound 4's estimate is 1.5-fold (0.18 log units) below it; the measured number falls inside the stated range.
By their numbers in this assay, from the lowest: compounds 3, 2, 1 and 4 (each within the scatter of the next, the first and the last beyond it).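

In this assay the choice between propyl and isopropyl at this place on the chain gives a readable difference: a 2.2-fold higher number from compound 3 to compound 4 (0.34 log units; beyond the scatter) is a modest step, but unlike the earlier step on this chain it lies beyond the scatter. By contrast, a 1.3-fold higher number from compound 2 to compound 4 (0.11 log units; within the scatter) and a 1.0-fold higher number from compound 1 to compound 4 (0.01 log units; within the scatter) both stay within the scatter, so neither that change of chain nor 4-methoxyphenyl in place of 3-methoxyphenyl on the nitrogen separates those pairs. Nothing available gives a cause for the step from propyl to isopropyl.

The compounds shown leave open how a longer chain, a cyclopropyl group or a terminal amine would read at this place. They also leave open whether any such group would bring the number far below the high values seen so far.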